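This account rests on a few compounds, and the source may have more. Where it says the series, first, only, none or still open, it means among the compounds named here.

Compound 3 `CC(=O)OCc1ccc2oc(=O)c(C(=O)Sc3cccc(Br)c3)cc2c1` belongs to a set of three esters that share one core and differ only in the group carried on the carbonyl carbon beside it. In a functional assay on HT-1080 cells (Homo sapiens), read by transwell migration, with a stated time of 24 h, tested at 10 uM (on this read-out lower numbers stand for a stronger effect and higher numbers for a weaker effect at the one concentration tested), compound 3 gives 67.8%. Compound 1 `CC(=O)OCc1ccc2oc(=O)c(C(=O)Sc3ccccc3)cc2c1`, the parent without a halogen, gives 73.8% in this assay, and compound 2 `CC(=O)OCc1ccc2oc(=O)c(C(=O)Sc3cccc(Cl)c3)cc2c1` gives 61.9%. The two halogen steps from the parent differ in size: a number 11.9 percentage points lower from compound 1 to compound 2 (beyond the scatter), whereas a number 6 percentage points lower from compound 1 to compound 3 (within the scatter). Between the two halogens themselves the gap is small, since a number 5.9 percentage points higher from compound 2 to compound 3 (within the scatter). Compound 3 therefore stands second highest of the three numbers, and neither of its neighbours is separated from it by more than the scatter.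

Compound 4 `CC(=O)OCc1ccc2oc(=O)c(C(=O)Nc3cccc(Cl)c3)cc2c1` is the next compound on this path. ((3-chlorophenyl)amino in place of (3-bromophenyl)sulfanyl on a carbonyl carbon). Going by the values given here, of the measured steps only the one between compound 2 and compound 3 bears on part of this change, the exchange of bromo for chloro, and it was within the scatter. Among the compounds with values here, no measured step speaks to the exchange of the sulfanyl link for the amino link, so the direction of that part is unknown. Compound 4 is therefore expected near the numbers already seen, with a number 2.8 percentage points lower from compound 3 to compound 4 (within the scatter) as the estimated step. The expected value for compound 4 is 65%, within an estimated range from 45% to 85%.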

Compound 4, a percentage reported as activity, at one concentration (the size of the read-out at that concentration, not a potency): 42.8%
Compound 4: the middle estimate sits 22.2 percentage points above what was measured, outside the stated range (below it).
By their numbers in this assay, from the lowest: compound 4; then compounds 2, 3 and 1 (each within the scatter of the next, the first and the last beyond it).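

Going by these compounds alone, the pair that keeps the 3-chlorophenyl ring fixed isolates the link on the carbonyl carbon, which no earlier step could address: in this assay, (3-chlorophenyl)amino in place of (3-chlorophenyl)sulfanyl gives a number 19.1 percentage points lower from compound 2 to compound 4 (beyond the scatter). The two steps that change the ring substituent as well as the link run the same way, with a number 25 percentage points lower from compound 3 to compound 4 (beyond the scatter) and a number 31 percentage points lower from compound 1 to compound 4 (beyond the scatter), whereas the exchange of halogen alone under the sulfanyl link gave only a number 5.9 percentage points higher from compound 2 to compound 3 (within the scatter). The data shown offer no explanation for what the change of link does to this read-out.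

The compounds shown leave open whether phenylamino or (3-bromophenyl)amino on the same carbonyl carbon would behave like compound 4, so the effect of the ring substituent under the amino link remains unknown. Also open, as far as these compounds go, is how a phenoxy group, or an N-methyl-N-(3-chlorophenyl)amino group lacking the amide hydrogen, would compare at this position, which leaves it undecided whether that hydrogen is needed for the lower number.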